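Piperazine amide series: a benzyl variant awaiting cytotoxicity data

The compounds below may be only part of what the source reports. "The series", "measured", "known", "first", "only" and "open" are said of these compounds alone.

Measured so far, in a functional assay on HT-29 cells (Homo sapiens) for cytotoxicity, read by MTT assay, with a stated time of 24 h, tested at 80 ug/mL; on this read-out lower numbers stand for a weaker effect and higher numbers for a stronger effect at the one concentration tested:
- compound 1, `Cn1c(-c2ccc(NC(=O)CSc3nc4ccccc4s3)cc2)nc(-c2ccccc2)c1-c1ccccc1`: 82.7%
- compound 2, `Cn1c(-c2ccc(NC(=O)CSC3=NCCS3)cc2)nc(-c2ccccc2)c1-c1ccccc1`: 75.2%
- compound 3, `CN(C)/C=C/N1CCN(CC(=O)Nc2ccc(-c3nc(-c4ccccc4)c(-c4ccccc4)n3C)cc2)CC1`: 45.4%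

Compound 3 stands lowest of the three in this assay; the nearest is compound 2, reached by a number 29.8 percentage points lower from compound 2 to compound 3 (beyond the scatter), and the furthest is compound 1, reached by a number 37.3 percentage points lower from compound 1 to compound 3 (beyond the scatter). Compounds 1 and 2 differ only by a number 7.5 percentage points lower from compound 1 to compound 2 (within the scatter).

Compound 4, `Cc1ccc(CN2CCN(CC(=O)Nc3ccc(-c4nc(-c5ccccc5)c(-c5ccccc5)n4C)cc3)CC2)cc1`, keeps the whole of compound 3 apart from one change: 4-methylbenzyl in place of 2-(dimethylamino)ethenyl on an amine nitrogen in a ring. For the measured compounds named here, no measured step alters the group on that amine nitrogen in a ring, so the steps from compound 1 and compound 2 to compound 3 bear only indirectly: they show that compound 3 sits well below the two sulfur-linked compounds, and both are large. Nothing measured says whether a 4-methylbenzyl on that ring nitrogen moves the number up or down, so no step beyond the scatter is expected, with wide uncertainty.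

Compound 4 is therefore estimated at 52%, within 28% to 76%, which means an expected step of a number 6.6 percentage points higher from compound 3 to compound 4 (within the scatter).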

Compound 4, a percentage reported as activity, at one concentration (the size of the read-out at that concentration, not a potency): 54.2%
The estimate for compound 4 lay 2.2 percentage points below the measured number; low and high end bracket the measured number.
By their numbers in this assay, from the lowest: compounds 3 and 4 (each within the scatter of the next); then compounds 2 and 1 (each within the scatter of the next).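

In this assay, for the compounds shown here, this is the first direct reading at the amine nitrogen in a ring: 4-methylbenzyl in place of 2-(dimethylamino)ethenyl gives a number 8.8 percentage points higher from compound 3 to compound 4 (within the scatter) at this position. This read-out therefore does not separate a group with no ring and one hydrogen-bond acceptor from one with a six-membered aromatic ring of carbon only and no hydrogen-bond acceptors. No supporting data bear on the result.

Going by these compounds, whether an unsubstituted benzyl, a longer chain or a carboxylic acid on that nitrogen would separate from compound 3 and compound 4 stays open. Also open, on these data alone, is whether any group there could reach the level of compound 2 at 75.2% and compound 1 at 82.7% in this single-concentration read-out.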